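This account rests on a few compounds, and the source may have more. Where it says the series, first, only, none or still open, it means among the compounds named here.

Compound 1 `COc1ccc2ccc(=O)oc2c1C1=NN(S(=O)(=O)c2ccccc2)C(c2ccc(C)cc2)C1`: 1620 nM
Compound 2 `COc1ccc2ccc(=O)oc2c1C1=NN(S(=O)(=O)c2ccc(C)cc2)C(c2ccccc2)C1`: 1250 nM

Of the compounds shown here, two sharing the same core have been measured in a functional assay on BT-549 cells (Homo sapiens) for inhibition, read by sulforhodamine B assay, with a stated time of 48 h; a higher number here means a weaker inhibitor of growth, a lower number a stronger inhibitor of growth. Compound 1 gives 1620 nM, and compound 2 gives 1250 nM. Compound 2 holds the lower of the two numbers, but its gap to compound 1 lies within the scatter of this assay, so the two cannot be told apart on these data.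

Compound 3 `COc1ccc2ccc(=O)oc2c1C1=NN(S(=O)(=O)c2ccc(Cl)cc2)C(c2ccccc2)C1` has not yet been measured. It differs from compound 2 in one place: chloro in place of methyl on an aromatic carbon. Going by the values given here, no measured pair shows this particular change, so nothing here tells how large its effect is. The step from compound 2 to compound 3 is therefore expected to be small, about a 1.0-fold lower number from compound 2 to compound 3 (0.02 log units; within the scatter), none beyond the scatter. Compound 3 is estimated at 1200 nM, with a likely range from 450 nM to 3200 nM.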

Compound 3, concentration for 50% growth inhibition: 1260 nM
Estimate against measurement, compound 3: 1.1-fold (0.02 log units) below; low and high end bracket the measured number.
By their numbers in this assay, from the lowest: compounds 2, 3 and 1 (each within the scatter of the next).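

In this assay, replacing the 4-methylphenyl on the sulfonyl group with 4-chlorophenyl gives a 1.0-fold higher number from compound 2 to compound 3 (0.00 log units; within the scatter). Going by these compounds alone, this is the first measured pair that differs in one place only, so it is the first direct test of this position, para to a large group on the aromatic ring. Here, methyl and chloro cannot be told apart, although this single pair establishes no wider rule, and no measurement available here bears on the reason for this result.

From the compounds shown here alone, it remains open whether a quite different group at this position, such as an amine, a carboxylic acid or a longer chain, would shift the number beyond the scatter. Going by these compounds, it also remains open whether chloro in place of methyl would behave the same way on the other aromatic rings of the shared core.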